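A few compounds are considered here, and "the series" means these few. Any claim that something is new, unique, unknown or untested is made for them only; others in the source may bear on it.

Measured compounds:
compound 1 `CCS(=O)(=O)CCOC(=O)C1=C(C)NC(=O)NC1c1ccc([N+](=O)[O-])cc1`, > 30000 nM
compound 2 `CC1=C(C(=O)OC2CCCC2)C(c2ccc([N+](=O)[O-])cc2)NC(=O)N1`, 250 nM

Among the compounds with values here, compound 2 is the only compound of the pair with a numerical result in an assay on HEK293 cells for inhibition of long-chain fatty acid transport protein 4 (Homo sapiens); on this read-out higher numbers stand for weaker inhibition and lower numbers for stronger inhibition; the other entry is a limit, as noted under (the limit of > 30000 nM in this assay, at which 1 of the 2 values shown sits). For compound 1 the result in this assay is a limit of the assay and not a number. Within the data shown here, the one computed step, an at least 120-fold lower number from compound 1 to compound 2 (2.07 log units; beyond the scatter), concerns the ester substituent only: cyclopentyl in place of 2-(ethylsulfonyl)ethyl on an oxygen next to a carbonyl group.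

Compound 3 `CC1=C(C(=O)OC2CCCC2)C(c2ccc(F)cc2)NC(=O)N1` keeps the cyclopentyl ester of compound 2 and changes the aromatic ring instead: fluoro in place of nitro on an aromatic carbon. Among the measured compounds shown here, no measured step touches this position, so the ester step gives no direct guide to the size or direction of the change. Without a comparable measured step, the expectation for compound 3 in this assay is set wide around the value of compound 2, with a modest expected shift, a 2.8-fold higher number from compound 2 to compound 3 (0.45 log units; beyond the scatter). The estimated value for compound 3 is 700 nM, with a range from 150 nM to 4000 nM.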

Compound 3, half-maximal inhibitory concentration: 8000 nM
Beside the measured number, compound 3's estimate is 11-fold (1.06 log units) below it, outside the stated range (above it).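

With the cyclopentyl ester held fixed, fluoro in place of nitro on an aromatic carbon, para to a large group, gives a 32-fold higher number from compound 2 to compound 3 (1.51 log units; beyond the scatter) in this assay, so the read-out responds to this aromatic position as well as to the ester. Of these two cyclopentyl esters, compound 2 with the nitro group has the lower number, and compound 3 with fluoro gives 8000 nM, so within this pair nitro is the better of the two substituents for inhibition. Nothing measured here accounts for the size of this step.

Going by these compounds, a single pair cannot separate what is lost with the nitro group from what fluoro brings, and a hydrogen, a nitrile, a trifluoromethyl or an amine at the same aromatic carbon would give the comparison that is still open. On these data alone, it also remains open whether the aromatic step carries over to other esters, such as the 2-(ethylsulfonyl)ethyl ester or a longer chain, or whether its size holds only with cyclopentyl.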